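The compounds below may be only part of what the source reports. "The series", "measured", "known", "first", "only" and "open" are said of these compounds alone.

Of the compounds shown here, three have so far been tested in a functional assay on MIA PaCa-2 cells (Homo sapiens) for inhibition, read by MTT assay, with a stated time of 3 days; on this read-out lower numbers stand for stronger inhibition and higher numbers for weaker inhibition. Compound 1 `CCOC(=O)[C@@H]1CCCN(S(=N)(=O)c2ccc(S(=O)(=O)N(CC)CC)cc2)C1` gives a reading in this assay that is a limit of the measurement rather than a number, > 10000 nM. Compound 2 `CCN(CC)S(=O)(=O)c1ccc(S(=O)(=O)N2CCC[C@@H](C(=O)N[C@@H]3CCN(C(=O)OC(C)(C)C)C3)C2)cc1` likewise gives only a limit in this assay, > 10000 nM. Compound 3 `CC(C)c1noc(N2CCN(C(=O)[C@@H]3CCCN(S(=O)(=O)c4ccc(S(=O)(=O)C5CCC5)cc4)C3)CC2)n1` also gives a limit in this assay, > 10000 nM. Compound 2 therefore stands at the same place as the other two: every reading sits at the limit of > 10000 nM in this assay, at which 3 of the 3 values shown sit, and none of them tells how far apart the compounds really are.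

Compound 4 `CCN(CC)S(=O)(=O)c1ccc(S(=O)(=O)N2CCC[C@@H](C(=O)NC3CN(C(=O)NC(C)(C)C)C3)C2)cc1` has not yet been tested. It differs from compound 2 in one place: 1-((tert-butyl)carbamoyl)azetidin-3-yl in place of 1-(tert-butoxycarbonyl)pyrrolidin-3-yl on an amide-type nitrogen. Going by the values given here, no step between two measured compounds is available to show how a change of this kind moves the reading. Because all readings so far sit at the limit of > 10000 nM in this assay, at which 3 of the 3 values shown sit, the expected step is none beyond the scatter, a step that the limit leaves unreadable from compound 2 to compound 4, and the reading is again expected to come out as a limit. Compound 4 is therefore estimated at 15000 nM, with a range from 5000 nM to 50000 nM.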

Compound 4, half-maximal inhibitory concentration: > 10000 nM
Compound 4: no number, only a limit; the forecaster's own chance of this, stated with the estimate: 80%; the middle value lies beyond the limit too.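

Compound 2 and compound 4 both give only a limit, so no step can be read from the swap of groups that separates them: the limit of > 10000 nM in this assay, at which 4 of the 4 values shown sit.

The compounds shown leave open how far apart they really lie, and which change, if any, would give a measurable number in this assay.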